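The compounds below may be only part of what the source reports. "The series", "measured", "known", "first", "only" and "open" are said of these compounds alone.

Measured so far in a functional assay on HCT-116 cells (Homo sapiens) for inhibition, read by MTT assay, with a stated time of 48 h; a lower number here means a stronger inhibitor, a higher number a weaker inhibitor:

Compound 1 `COc1ccc(-n2c(SCC(=O)c3ccc4ccccc4c3)nnc2-c2cc(OC)c(OC)c(OC)c2)cc1`: > 60000 nM, a limit of the assay and not a number
Compound 2 `COc1cc(-c2nnc(SCC(=O)c3ccccc3)n2-c2ccc(N(C)C)cc2)cc(OC)c1OC`: 42500 nM

Among the measured compounds shown here, compound 2 holds the only true number in this small set, so there is no spread of values against which to rank it. Compound 1 has only a limit, as this record shows: the limit of > 60000 nM in this assay, at which 1 of the 2 values shown sits.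

The next compound, compound 3 `COc1cc(-c2nnc(SCC(=O)c3ccc4ccccc4c3)n2-c2ccc(N(C)C)cc2)cc(OC)c1OC`, is made from compound 2 by a single change: naphthalen-2-yl in place of phenyl on a carbonyl carbon. In counted terms, the change is naphthalen-2-yl in place of phenyl on a carbonyl carbon.

For the measured compounds named here, no two measured compounds differ in just one place, so the data give no direct measure of what such a change does. The expectation is therefore a loose one. Compound 2, at 42500 nM, leaves far more room for a stronger result than for a weaker one. A moderate gain in strength is expected, with the estimated step being a 2.8-fold lower number from compound 2 to compound 3 (0.45 log units; beyond the scatter). A result reported only as a limit remains possible.

For compound 3 the estimate in this assay is 15000 nM, with an expected range from 2500 nM to 60000 nM.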

Compound 3, half-maximal inhibitory concentration: 54500 nM
Beside the measured number, compound 3's estimate is 3.6-fold (0.56 log units) below it; the range from low to high includes it.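

In this assay, among the compounds shown here, the swap of phenyl for naphthalen-2-yl on a carbonyl carbon gives the first direct reading at this position: a 1.3-fold higher number from compound 2 to compound 3 (0.11 log units; within the scatter). On this evidence, adding the second aromatic ring does not separate the two compounds, which sit close together at the weak end of the scale. The other step, dimethylamino in place of methoxy on an aromatic carbon, is an at least 1.1-fold lower number from compound 1 to compound 3 (0.04 log units; that floor lies within the scatter), and it gives only a floor, as compound 1 has a limit of the assay and not a number: the limit of > 60000 nM in this assay, at which 1 of the 3 values shown sits.

The compounds shown leave open whether any other group on this carbonyl carbon, such as a pyridine ring, a cyclohexyl ring or a plain methyl, would move the number beyond the scatter, and whether an amine or a carboxylic acid on the ring there would do so. From the compounds shown here alone, the true size of the change from methoxy to dimethylamino also stays open, since a floor within the scatter cannot show whether that swap matters at all.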